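Alkynyl branch on the amine nitrogen of compound 1

The source may hold more compounds than are shown below. What is called first, only, known or untested is meant among the compounds shown, and "the series" means these compounds.

For the measured compounds named here, compound 1 `CC(C)N(CC[C@H](N)C(=O)O)C[C@H]1O[C@@H](n2cnc3c(N)ncnc32)[C@H](O)[C@@H]1O` stands lowest of the two numbers measured so far: in an assay for inhibition of tRNA (cytosine(38)-C(5))-methyltransferase (Homo sapiens), with a stated time of 5 min, tested at 100 uM (on this read-out higher numbers stand for more inhibition at the one concentration tested (going by the name of the read-out) and lower numbers for less inhibition), compound 1 gives 44%, and its only neighbour is compound 2 `C#CCN(CC[C@H](N)C(=O)O)C[C@H]1O[C@@H](n2cnc3c(N)ncnc32)[C@H](O)[C@@H]1O`, which in this assay gives 72.2%. Going by the values given here, the one measured step, a number 28.2 percentage points higher from compound 1 to compound 2 (beyond the scatter), exchanges isopropyl for propargyl on the amine nitrogen and lies beyond the scatter. Compound 3 `C#CC(C)(C)N(CC[C@H](N)C(=O)O)C[C@H]1O[C@@H](n2cnc3c(N)ncnc32)[C@H](O)[C@@H]1O` keeps the branching of compound 1 and adds the triple bond: ethynyl in place of hydrogen on a saturated chain carbon bound to an amine nitrogen and two saturated chain carbons. Among the compounds with values here, only the step from compound 1 to compound 2 bears on this change, as it introduces the same triple bond, though on an unbranched chain; no measured compound carries branching and triple bond together. A rise in this assay is therefore expected, with its size uncertain, the estimated step being a number 14 percentage points higher from compound 1 to compound 3 (beyond the scatter). For compound 3 the estimate in this assay is 58%, within 35% to 80%.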

Compound 3, a percentage reported as inhibition, at one concentration (the size of the read-out at that concentration, not a potency): 17.3%
Compound 3: the middle estimate sits 40.7 percentage points above what was measured; measured number below the stated range.
By their numbers in this assay, from the lowest: compound 3; then compound 1; then compound 2.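

In this assay the triple bond brings no gain of its own: ethynyl in place of hydrogen on a saturated chain carbon bound to an amine nitrogen and two saturated chain carbons gives a number 26.7 percentage points lower from compound 1 to compound 3 (beyond the scatter) and so runs against a number 28.2 percentage points higher from compound 1 to compound 2 (beyond the scatter), which also brings in a triple bond. Exchanging propargyl for 1,1-dimethylprop-2-yn-1-yl gives a number 54.9 percentage points lower from compound 2 to compound 3 (beyond the scatter), so across these three compounds the outcome of carrying a triple bond on this amine nitrogen differs with the chain that holds it. No measurement bearing on the cause of these steps is at hand.

As far as these compounds go, whether the fall belongs to the two methyl groups themselves or to their combination with the triple bond stays open, and a tert-butyl group on the same amine nitrogen would separate the two. From the compounds shown here alone, how a but-2-yn-1-yl group, a longer unbranched chain with a triple bond, would compare with propargyl also stays open.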